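Heteroaryl exchange on the amine-bound chain carbon

This account rests on a few compounds, and the source may have more. Where it says the series, first, only, none or still open, it means among the compounds named here.

Numbers in hand, all from an assay on isolated protein for displacement of a labelled ligand from Gonadotropin-releasing hormone receptor (Homo sapiens); on this read-out higher numbers stand for weaker inhibition and lower numbers for stronger inhibition:
compound 1 `Cc1nc(C)c(CN2CCN(c3cccc4[nH]c(-c5ccc(C(C)(C)C)cc5)nc34)CC2)s1`: 27 nM
compound 2 `CCc1nc(C)c(CN2CCN(c3cccc4[nH]c(-c5ccc(C(C)(C)C)cc5)nc34)CC2)s1`: 20 nM
compound 3 `Cc1n[nH]c(C)c1CN1CCN(c2cccc3[nH]c(-c4ccc(C(C)(C)C)cc4)nc23)CC1`: 68 nM

Compound 3 carries the highest number of the three. Its distance to the others is given by a 2.5-fold higher number from compound 1 to compound 3 (0.40 log units; beyond the scatter) and by a 3.4-fold higher number from compound 2 to compound 3 (0.53 log units; beyond the scatter), both beyond the scatter and both modest; the step of a 1.4-fold lower number from compound 1 to compound 2 (0.13 log units; within the scatter) between the two thiazole compounds stays within it.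

Compound 4 `Cc1nc(CN2CCN(c3cccc4[nH]c(-c5ccc(C(C)(C)C)cc5)nc34)CC2)cn1C` is the next member. Relative to compound 3 the change is 1,2-dimethyl-1H-imidazol-4-yl in place of 3,5-dimethyl-1H-pyrazol-4-yl on a saturated chain carbon bound to an amine nitrogen in a ring. Among the compounds with values here, the steps that bear on this position are the two ring exchanges into compound 3 from compound 1 and from compound 2; each moved this assay modestly and in the direction of a higher number. Within the data shown here, no measured step involves an imidazole, so the size of the new exchange is not anchored. Compounds 1 and 2, which like compound 4 have no hydrogen-bond donor on this ring, sit lower than compound 3. On that basis a modest move back toward lower numbers is expected, a 1.5-fold lower number from compound 3 to compound 4 (0.18 log units; within the scatter). Compound 4 is therefore estimated at 45 nM, within a range from 15 nM to 150 nM.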

Compound 4, half-maximal inhibitory concentration: 10 nM
Compound 4: middle estimate off by 4.5-fold (0.65 log units), on the high side, and the stated range ends above it.
By their numbers in this assay, from the lowest: compounds 4, 2 and 1 (each within the scatter of the next, the first and the last beyond it); then compound 3.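

In this assay, within the data shown here, the exchange of 3,5-dimethyl-1H-pyrazol-4-yl for 1,2-dimethyl-1H-imidazol-4-yl gives a 6.8-fold lower number from compound 3 to compound 4 (0.83 log units; beyond the scatter) and is the largest step so far at this position, although the two compounds have the same atoms joined differently. The imidazole also separates from one thiazole but not the other, with a 2.7-fold lower number from compound 1 to compound 4 (0.43 log units; beyond the scatter) beyond the scatter and a 2.0-fold lower number from compound 2 to compound 4 (0.30 log units; within the scatter) within it, so changing the ring does not set compound 4 clear of both thiazole compounds. No measurement is available to explain these steps.

Compound 3 alone carries a hydrogen-bond donor on this ring, so a single compound cannot tie its higher number to that count. Still open, from the compounds shown here alone, is how a pyridine or an unmethylated 1H-imidazol-4-yl on the same chain carbon would read.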